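The compounds below may be only part of what the source reports. "The series", "measured", "known", "first", "only" and "open" are said of these compounds alone.

Among the measured compounds shown here, compound 1 `CC1=CC[C@H](C(C)C)c2cc(C)c(OC(=O)c3ccc(Cl)cc3)cc21` is one of three compounds measured in a functional assay on PC-3 cells (Homo sapiens) for antiproliferative activity, read by sulforhodamine B assay, with a stated time of 48 h, tested at 50 uM; on this read-out higher numbers stand for more inhibition at the one concentration tested (going by the name of the read-out) and lower numbers for less inhibition. Compound 1 gives 34.1%, which places it second highest of the three numbers. The highest number belongs to compound 2 `Cc1cc2c(C(C)C)ccc(C)c2cc1OC(=O)c1ccc([N+](=O)[O-])cc1`, which in this assay gives 100%. The lowest belongs to compound 3 `COc1cccc(C(=O)Oc2cc3c(C)ccc(C(C)C)c3cc2C)c1`, which in this assay gives 12.5%. Compound 1 lies nearer to compound 3 than to compound 2, and both gaps are beyond the scatter. For the measured compounds named here, the one step between compounds differing in a single place is a number 87.5 percentage points lower from compound 2 to compound 3 (beyond the scatter), a change of the aryl group on the carbonyl carbon of the ester.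

Compound 4 `CC1=CC[C@H](C(C)C)c2cc(C)c(OC(=O)c3ccc(C)cc3)cc21` has not yet been measured. It differs from compound 1 by methyl in place of chloro on an aromatic carbon. Going by the values given here, no measured step swaps chloro for methyl. The step from compound 2 to compound 3 shows that the group on the ester aryl ring can shift the read-out very widely, but it is a different exchange on a different core and gives no direction here. The leaving group and the entering group are alike in every feature counted for the difference, so only a small step is expected. Compound 4 is therefore expected to give about 30% in this assay, with a likely range from 10% to 55%. This estimate means an expected step of a number 4.1 percentage points lower from compound 1 to compound 4 (within the scatter), one within the usual scatter.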

Compound 4, a percentage reported as inhibition, at one concentration (the size of the read-out at that concentration, not a potency): 49.6%
Estimate against measurement, compound 4: 19.6 percentage points below; low and high end bracket the measured number.
By their numbers in this assay, from the lowest: compound 3; then compound 1; then compound 4; then compound 2.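

Among the compounds shown here, exchanging chloro for methyl on the aromatic carbon para to a large group gives, in this assay, a number 15.5 percentage points higher from compound 1 to compound 4 (beyond the scatter), the first reading of a change at this position on this core. The step lies beyond the scatter although the leaving and entering groups each hold 1 heavy atom, and neither carries a ring, a hydrogen-bond donor or acceptor, or a net charge, so the features counted here do not separate the two groups. The earlier step involved a different exchange on a different core, whereas this one shows that a single-atom exchange at this position can itself move the read-out on the core of compound 1, and none of the information available here explains why the number moves in this direction.

On these data alone, what an amine, a carboxylic acid or a longer chain such as propyl would do at this same position on the core of compound 1 remains open, so two groups here do not yet define a trend for the position. As far as these compounds go, it is also open whether the same exchange of chloro for methyl would move the number in the same direction on the core of compound 2.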